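Adding 2-hydroxyethyl to compound 1 on an aromatic nitrogen

The source may report more compounds than this note shows. Statements on the series, on what has been measured and on what is new or still open speak of the compounds shown alone.

Compound 1 (`c1ccc(CSc2nc(-c3cc4ccccc4[nH]3)n[nH]2)cc1`) is the reference point for this step. Within the data shown here, in a functional assay on MCF7 cells (Homo sapiens) for antiproliferative activity, read by sulforhodamine B assay, with a stated time of 48 h (a lower number here means a stronger inhibitor, a higher number a weaker inhibitor), compound 1 gives 4.53 ug/mL, the lower of the two numbers measured so far. Compound 2 (`CC(=O)OC[C@H]1O[C@@H](n2nc(SCc3ccccc3)nc2-c2cc3ccccc3[nH]2)[C@H](OC(C)=O)[C@@H](OC(C)=O)[C@@H]1OC(C)=O`), which carries a different and larger substituent on an aromatic nitrogen, gives 16 ug/mL in this assay, a higher number by a gap beyond the scatter. The two compounds differ in more than one place, so the data hold no direct measure of a single change.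

Compound 3 (`OCCn1nc(-c2cc3ccccc3[nH]2)nc1SCc1ccccc1`) has 2-hydroxyethyl in place of hydrogen on an aromatic nitrogen of compound 1 (2-hydroxyethyl in place of hydrogen on an aromatic nitrogen). Among the measured compounds shown here, the only guide is compound 2 (16 ug/mL), where a substituent on an aromatic nitrogen comes with a higher number, and one compound sets no rule. A shift toward a weaker inhibitor is expected, smaller than the gap seen for compound 2, and no shift beyond the scatter remains possible. The expected step is a 2.2-fold higher number from compound 1 to compound 3 (0.34 log units; beyond the scatter), and it is only an estimate. Compound 3 is expected at 10 ug/mL, with an estimated range from 3.5 ug/mL to 28 ug/mL in this assay.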

Compound 3, half-maximal inhibitory concentration: 14.6 ug/mL
For compound 3 the middle estimate is 1.5-fold (0.16 log units) below the measured one; measured number inside the range.
By their numbers in this assay, from the lowest: compound 1; then compounds 3 and 2 (each within the scatter of the next).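

Among these compounds, the first single-change reading at this position is a 3.2-fold higher number from compound 1 to compound 3 (0.51 log units; beyond the scatter) in this assay, for 2-hydroxyethyl in place of hydrogen on an aromatic nitrogen. Replacing this hydrogen therefore gives a weaker inhibitor, though only by a modest step, and compound 3 still gives a measured value in the same assay. No measurement available here bears on why the number rises with this change.

From the compounds shown here alone, whether the higher number comes with any substituent on this aromatic nitrogen or with 2-hydroxyethyl in particular remains open, and a methyl group, a longer chain ending in a hydroxyl, an aminoethyl chain or a carboxylic acid on the same nitrogen would separate these cases. Also open, going by these compounds, is whether the step keeps its size when the benzylsulfanyl group on the neighbouring ring atom is replaced, for example by a methylsulfanyl group, since both compounds in this step carry the benzylsulfanyl group unchanged.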